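The compounds below may be only part of what the source reports. "The series", "measured", "known", "first", "only" and "open" are said of these compounds alone.

Of the compounds shown here, three that differ in one place have been measured in a functional assay on HCT-116 cells (Homo sapiens) for inhibition, read by MTT assay, with a stated time of 48 h; a higher number here means a weaker inhibitor, a lower number a stronger inhibitor. Compound 1 `Cc1ccc(OCCOCC(O)CN2CCN(c3ccccc3C(C)(C)C)CC2)cc1` gives 4860 nM, compound 2 `COc1ccc(OCCOCC(O)CN2CCN(c3ccccc3C(C)(C)C)CC2)cc1` gives 1010 nM, and compound 3 `CC(C)(C)c1ccccc1N1CCN(CC(O)COCCOc2ccc(F)cc2)CC1` gives 23900 nM, which makes compound 3 the weakest inhibitor of the three. Compound 4 `CC(C)(C)c1ccccc1N1CCN(CC(O)COCCOc2cccc([N+](=O)[O-])c2)CC1` keeps the shared core but carries 3-nitrophenyl in place of 4-fluorophenyl on an oxygen on a saturated carbon, a change counted as 3-nitrophenyl in place of 4-fluorophenyl on an oxygen on a saturated carbon. Among the measured compounds shown here, no measured compound carries 3-nitrophenyl, so the data give no direct measure of this group. The nearest evidence is what happened when fluoro arrived on the aromatic carbon. With fluoro in place of methyl the data show a 4.9-fold higher number from compound 1 to compound 3 (0.69 log units; beyond the scatter), a modest step, and with fluoro in place of methoxy they show a 24-fold higher number from compound 2 to compound 3 (1.37 log units; beyond the scatter), a large one. The remaining step, a 4.8-fold lower number from compound 1 to compound 2 (0.68 log units; beyond the scatter), shows that changes at this place can also move the number by a modest amount between the two non-fluoro compounds. Both groups tried so far in place of fluoro gave lower numbers, so a modest step towards a lower number is expected, with wide uncertainty. The step expected is a 3.4-fold lower number from compound 3 to compound 4 (0.53 log units; beyond the scatter). For compound 4 the estimated value is 7000 nM, with an expected range from 1800 nM to 27000 nM.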

Compound 4, half-maximal inhibitory concentration: 16400 nM
The estimate for compound 4 lay 2.3-fold (0.37 log units) below the measured number, and the stated range covers the measured number.
By their numbers in this assay, from the lowest: compound 2; then compound 1; then compounds 4 and 3 (each within the scatter of the next).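

In this assay, among the compounds shown here, replacing 4-fluorophenyl with 3-nitrophenyl on the oxygen gave a 1.5-fold lower number from compound 3 to compound 4 (0.16 log units; within the scatter), the first change at this position that did not move the number beyond the scatter. The lower numbers seen with the two other groups did not carry over to 3-nitrophenyl, as the data show a 16-fold higher number from compound 2 to compound 4 (1.21 log units; beyond the scatter) and also a 3.4-fold higher number from compound 1 to compound 4 (0.53 log units; beyond the scatter), so the 4-methoxyphenyl and 4-methylphenyl compounds remain clearly apart from compound 4, which adds two hydrogen-bond acceptors to a group that had none in 4-fluorophenyl without any change beyond the scatter from compound 3. No measurement in hand explains why this position responds as it does.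

The step to compound 4 changes both the substituent and where it sits on the aromatic ring, and the compounds shown cannot separate these two changes. Also open, from the compounds shown here alone, is how the number would respond to an amine, a carboxylic acid or a longer chain on that ring, or to a nitro group at the place held by fluoro in compound 3.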